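Working notes on a 4-bromophenyl series and a fluoro addition

The source may report more compounds than this note shows. Statements on the series, on what has been measured and on what is new or still open speak of the compounds shown alone.

Measured so far in a functional assay on MCF7 cells (Homo sapiens) for cytotoxicity, read by MTT assay, with a stated time of 72 h; a lower number here means a stronger inhibitor, a higher number a weaker inhibitor:
- compound 1 `Cn1ccc2c(Oc3ccc(NC(=O)c4nn(-c5ccc(Cl)cc5)ccc4=O)cc3F)ccnc21`: compound 1 gives > 60000 nM, a limit of the assay.
- compound 2 `COc1ccc(-n2ccc(=O)c(C(=O)Nc3ccc(Oc4ccnc5c4ccn5C)c(F)c3)n2)cc1`: compound 2 gives > 60000 nM, a limit of the assay.
- compound 3 `Cn1ccc2c(Oc3ccc(NC(=O)c4nn(-c5ccc(Br)cc5)ccc4=O)cc3F)ccnc21`: compound 3 gives 33600 nM.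

Within the data shown here, compound 3 is the only member of the set that yields a number in this assay; the other two values are limits, as the limit of > 60000 nM in this assay, at which 2 of the 3 values shown sit, records. The step of an at least 1.7-fold lower number from compound 1 to compound 3 (0.25 log units; that floor lies within the scatter) and the step of an at least 1.7-fold lower number from compound 2 to compound 3 (0.25 log units; that floor lies within the scatter) each rest on a limit and sit at a floor within the usual scatter, so neither shows a real change. The step that the two limits leave unreadable from compound 1 to compound 2 cannot be read at all.

Compound 4 `Cn1ccc2c(Oc3ccc(NC(=O)c4nn(-c5ccc(Br)cc5F)ccc4=O)cc3F)ccnc21` differs from compound 3 by fluoro in place of hydrogen on an aromatic carbon. Among the measured compounds shown here, none of the measured steps concerns a fluoro entering on that ring; they only exchange the group already present, and none of them reaches beyond the scatter. No direction can be drawn from them, so the expected step of no change at the digits printed from compound 3 to compound 4 (within the scatter) is none beyond the scatter. Compound 4 is therefore estimated at 33600 nM in this assay, with a range from 12000 nM to 90000 nM, and a limit rather than a number remains a real possibility.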

Compound 4, half-maximal inhibitory concentration: 14100 nM
Estimate against measurement, compound 4: 2.4-fold (0.38 log units) above, within the range that was stated.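

In this assay, among these compounds, fluoro in place of hydrogen on this aromatic carbon, ortho to a large group, gives a 2.4-fold lower number from compound 3 to compound 4 (0.38 log units; beyond the scatter), the first step in the set that rests on two numbers and lies beyond the scatter. Steps from the limit compounds also become readable beyond the scatter: 4-bromo-2-fluorophenyl in place of 4-methoxyphenyl gives an at least 4.2-fold lower number from compound 2 to compound 4 (0.62 log units; beyond the scatter), and 4-bromo-2-fluorophenyl in place of 4-chlorophenyl gives an at least 4.2-fold lower number from compound 1 to compound 4 (0.62 log units; beyond the scatter). Both of these are floors, not full sizes, and they rest on a limit: the limit of > 60000 nM in this assay, at which 2 of the 4 values shown sit.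

From the compounds shown here alone, the step between the two limit compounds still cannot be read, and whether the fluoro step carries over to the 4-chlorophenyl or 4-methoxyphenyl compounds stays open. Also open, going by these compounds, is how an amine or a hydroxyl group in place of the fluoro would compare.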